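This account rests on a few compounds, and the source may have more. Where it says the series, first, only, none or still open, it means among the compounds named here.

Compound 1 `CCOC(=O)C1=Cc2ccccc2OC1(OCc1cc(-c2ccc(OC)cc2)no1)C(F)(F)F`, compound 2 `CCOC(=O)C1=Cc2ccccc2OC1(OCc1cn(-c2ccc(C)cc2)nn1)C(F)(F)F` and compound 3 `CCOC(=O)C1=Cc2ccccc2OC1(OCc1cn(CC(=O)Nc2cccc(F)c2)nn1)C(F)(F)F` share one core and differ only in the group attached to it through the ether oxygen. In a functional assay on DU-145 cells (Homo sapiens) for inhibition, read by MTT assay, with a stated time of 24 h (a higher number here means a weaker inhibitor, a lower number a stronger inhibitor), compound 1 reaches only the limit of the assay and gives > 150000 nM, which is a limit rather than a number. In this assay compound 2 gives 30200 nM. In this assay compound 3 again reports only a limit, > 150000 nM. Among the measured compounds shown here, the single step between neighbours, an at least 4.9-fold higher number from compound 2 to compound 3 (0.69 log units; beyond the scatter), is therefore known only as a bound, since compound 3 sits at the limit of > 150000 nM in this assay, at which 2 of the 3 values shown sit. Compound 4 `CCOC(=O)C1=Cc2ccccc2OC1(OCc1cn(CC(=O)Nc2ccc(C)cc2)nn1)C(F)(F)F` differs from compound 3 by 4-methylphenyl in place of 3-fluorophenyl on an amide-type nitrogen. For the measured compounds named here, no measured step isolates this exchange of one six-membered aromatic ring for another on the amide-type nitrogen, and the only related step ends at a limit rather than a number. Compound 4 is expected to stay near that limit, with an expected step of an at least 1.1-fold lower number from compound 3 to compound 4 (0.06 log units; that floor lies within the scatter). The estimate for compound 4 in this assay is 130000 nM, within 30000 nM to 300000 nM.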

Compound 4, half-maximal inhibitory concentration: > 150000 nM
Compound 4 gave a limit, no number; the forecaster's own chance of this, stated with the estimate: 60%; middle value at least 1.1-fold (0.06 log units) away from the limit.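

Compound 3 and compound 4 each report only a limit in this assay, and the step between them cannot be read. Putting ((4-methylphenyl)carbamoyl)methyl in place of 4-methylphenyl on the aromatic nitrogen gives an at least 4.9-fold higher number from compound 2 to compound 4 (0.69 log units; beyond the scatter), so the loss seen with the 3-fluorophenyl amide also appears when the same 4-methylphenyl ring is kept at both ends of the step. Both amides shown therefore sit at the limit, but compound 1, which has no such amide, goes against tying that limit to the amide alone: the limit of > 150000 nM in this assay, at which 3 of the 4 values shown sit.

From the compounds shown here alone, whether exchanging 3-fluorophenyl for 4-methylphenyl changes the true potency at all stays unknown. Also open, going by these compounds, is whether an amine or a carboxylic acid in place of the aromatic ring on the amide-type nitrogen would give a readable number in this assay.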